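Ester in place of primary amide on the shared core

The compounds below may be only part of what the source reports. "The series", "measured", "known", "first", "only" and "open" are said of these compounds alone.

Compound 1 `NC(=O)c1ccc2c(ccn2-c2ccc(NC(=O)c3cccc(C(F)(F)F)c3)cc2)n1` is tested in a functional assay on A375P cells (Homo sapiens) for cytotoxicity, read by MTT assay; a lower number here means a stronger inhibitor, a higher number a weaker inhibitor. In this assay compound 1 reaches only the limit > 10000 nM, so no number stands for it. Compound 2 `NC(=O)c1ccc2c(ccn2-c2ccc(NC(=O)c3ccc(Cl)c(C(F)(F)F)c3)cc2)n1` differs by chloro in place of hydrogen on an aromatic carbon, and in this assay compound 2 gives 8900 nM. Within the data shown here, the one measured step, an at least 1.1-fold lower number from compound 1 to compound 2 (0.05 log units; that floor lies within the scatter), carries only a floor because of the limit of > 10000 nM in this assay, at which 1 of the 2 values shown sits. Compound 3 `COC(=O)c1ccc2c(ccn2-c2ccc(NC(=O)c3cccc(C(F)(F)F)c3)cc2)n1` is not yet measured and differs from compound 1 at the carbonyl carbon: methoxy in place of amino on a carbonyl carbon. Among the measured compounds shown here, no measured step touches that position, so the chloro step between compound 1 and compound 2 gives no guide to it. Compound 1 sits at the limit of this assay, and nothing in the series points to a sizeable fall from there. For compound 3 the expected value in this assay is 12000 nM, with a range of 5000 nM to 30000 nM. The step from compound 1 is estimated as a step that the limit leaves unreadable from compound 1 to compound 3, and a report of only a limit is likely.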

Compound 3, half-maximal inhibitory concentration: 9500 nM
Beside the measured number, compound 3's estimate is 1.3-fold (0.10 log units) above it; the range from low to high includes it.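

Methoxy in place of amino on a carbonyl carbon gives an at least 1.0-fold lower number from compound 1 to compound 3 (0.02 log units; that floor lies within the scatter). The real size of this step cannot be read, because its floor rests on a limit for compound 1: the limit of > 10000 nM in this assay, at which 1 of the 3 values shown sits. Compound 3 still adds one point that the chloro step could not show: on the shared core, a measured value in this assay does not depend on the amino group at this carbonyl carbon, and the change from carbamoyl to methoxycarbonyl gives no sign of a loss.

From the compounds shown here alone, it remains open how a carboxylic acid or a longer ester such as ethoxycarbonyl would read at this position, and whether any group here moves the value beyond the scatter. Also open, going by these compounds, is how methoxycarbonyl behaves together with the chloro group in a single compound.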